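Methoxy Loss on the Aryl Ring of a Pyrazolyl Chalcone

The source may hold more compounds than are shown below. What is called first, only, known or untested is meant among the compounds shown, and "the series" means these compounds.

Measured compounds:
Compound 1, `COc1cc(-c2cc(/C=C/C(=O)c3ccc(N)cc3)[nH]n2)cc(OC)c1OC`: 8660 nM
Compound 2, `COc1ccc(-c2cc(/C=C/C(=O)c3ccc(N)cc3)[nH]n2)cc1OC`: 45700 nM
Compound 3, `COc1cc(C(=O)/C=C/c2cc(-c3cc(OC)c(OC)c(OC)c3)n[nH]2)cc(OC)c1OC`: 5710 nM

The three compounds were tested in a functional assay on UACC-257 cells (Homo sapiens) for inhibition, read by sulforhodamine B assay, with a stated time of 48 h; on this read-out lower numbers stand for higher toxicity in this test and higher numbers for lower toxicity in this test. Compound 1 and compound 2 differ in one place, (hydrogen in place of methoxy on an aromatic carbon), and that change gave a 5.3-fold higher number from compound 1 to compound 2 (0.72 log units; beyond the scatter). Compound 3 stands with the lowest number of the three; its gap to compound 1 lies within the scatter, while its gap to compound 2 lies beyond it. The difference between the core of compound 3 and the core of compound 1 is not broken down here.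

Compound 4, `COc1ccc(-c2cc(/C=C/C(=O)c3cc(OC)c(OC)c(OC)c3)[nH]n2)cc1OC`, has not been measured. It differs from compound 3 by hydrogen in place of methoxy on an aromatic carbon, the same change that was made from compound 1 to compound 2, occurring twice among these compounds. In this assay the step from compound 3 to compound 4 is expected to be a 4.6-fold higher number from compound 3 to compound 4 (0.66 log units; beyond the scatter). This expectation rests on compound 1 and compound 2, where the same change gave a 5.3-fold higher number from compound 1 to compound 2 (0.72 log units; beyond the scatter). Compound 4 is therefore estimated at 26000 nM, with a range from 8000 nM to 85000 nM.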

Compound 4, concentration lethal to 50% of the cells: 8050 nM
The estimate for compound 4 lay 3.2-fold (0.51 log units) above the measured number, within the range that was stated.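

In this assay the replacement of methoxy by hydrogen gave a 1.4-fold higher number from compound 3 to compound 4 (0.15 log units; within the scatter) on the core of compound 3, a much smaller step than the one seen on the core of compound 1. The two steps do not agree, so the size of this change did not carry from one core to the other: the same change on two cores in this assay, a 5.3-fold higher number (0.72 log units; beyond the scatter) from compound 1 to compound 2 and a 1.4-fold higher number (0.15 log units; within the scatter) from compound 3 to compound 4, 3.7-fold (0.57 log units) apart, beyond the scatter of two such steps. This shows that, for these two cores, the step measured on one core is a poor guide to the step on the other, but it does not show which difference between the cores is responsible, and two steps cannot establish a rule for the series.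

As far as these compounds go, it remains open whether a hydroxy group or a fluorine atom in place of the lost methoxy would behave as hydrogen does. From the compounds shown here alone, it also remains open whether the same change on a third core would give a step nearer the larger or the smaller of these two.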